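This account rests on a few compounds, and the source may have more. Where it says the series, first, only, none or still open, it means among the compounds named here.

Working notes on the series.

The shared core is held by all compounds here; the variation sits on the amine nitrogen at the far end of the chain. Compound 1 `COc1ccc(NC[C@H](O)COc2ccc(N3C[C@H](CNC(C)=O)OC3=O)cc2F)cc1` carries a 4-methoxyphenyl group there and in a physicochemical assay for solubility, read by HPLC (a higher number here means a more soluble compound, a lower number a less soluble compound), compound 1 gives 56000 nM. Compound 2 `CC(=O)NC[C@H]1CN(c2ccc(OC[C@H](O)CNc3ccccc3)c(F)c2)C(=O)O1` carries a plain phenyl group, and in this assay compound 2 gives 296000 nM. Compound 3 `CC(=O)NC[C@H]1CN(c2ccc(OC[C@@H](O)CNc3ccc(C#N)cc3)c(F)c2)C(=O)O1` carries a 4-cyanophenyl group, and in this assay compound 3 gives 47000 nM. Among these three numbers compound 1 stands second highest: compound 3 is nearest, the step of a 1.2-fold lower number from compound 1 to compound 3 (0.08 log units; within the scatter) lying within the scatter, while compound 2 is furthest, its number well above that of compound 1 and beyond the scatter.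

Compound 4 `CC(=O)NC[C@H]1CN(c2ccc(OC[C@@H](O)CNc3ccncc3)c(F)c2)C(=O)O1` is the next member, not yet measured in this assay. It differs from compound 1 by pyridin-4-yl in place of 4-methoxyphenyl on an amine nitrogen. For the measured compounds named here, the only measured step at this position, a 1.2-fold lower number from compound 1 to compound 3 (0.08 log units; within the scatter), was within the scatter, so a swap of the aromatic group here need not move the number much; the higher value of compound 2 shows that a change at this position can also raise it beyond the scatter. On that basis a modest rise is expected, a 2.1-fold higher number from compound 1 to compound 4 (0.33 log units; beyond the scatter), and compound 4 is estimated at 120000 nM, within a range from 45000 nM to 320000 nM.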

Compound 4, solubility: 17700000 nM
For compound 4 the middle estimate is 150-fold (2.17 log units) below the measured one, outside the stated range (above it).
By their numbers in this assay, from the lowest: compounds 3 and 1 (each within the scatter of the next); then compound 2; then compound 4.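

In this assay, for the compounds shown here, the aromatic group on this amine nitrogen proves able to move the number far more than the earlier compounds showed: pyridin-4-yl in place of 4-methoxyphenyl gives a 320-fold higher number from compound 1 to compound 4 (2.50 log units; beyond the scatter) and pyridin-4-yl in place of 4-cyanophenyl gives a 380-fold higher number from compound 3 to compound 4 (2.58 log units; beyond the scatter) as large steps, against a 1.2-fold lower number from compound 1 to compound 3 (0.08 log units; within the scatter) between the two carbon-only rings bearing a substituent. Compound 4 also clears the earlier highest number, with a 60-fold higher number from compound 2 to compound 4 (1.78 log units; beyond the scatter) as the step, but that step is written on the whole 1-hydroxy-2-((pyridin-4-yl)amino)ethyl group in place of 2-anilino-1-hydroxyethyl, so it does not isolate the aromatic ring. Going by these compounds alone, compound 4 is the only compound here whose aromatic ring holds a hetero atom, and no measurement at hand accounts for a change of this size.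

With a single such ring, the compounds shown leave open whether the rise follows the ring hetero atom or belongs to pyridin-4-yl alone. Also open, from the compounds shown here alone, is what pyridin-3-yl, pyridin-2-yl or a saturated piperidin-4-yl ring on the same amine nitrogen would give in this assay and whether any of them would reach the same range.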